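Ortho Substituents on the Benzylidene Ring and Cytotoxicity

The source may report more compounds than this note shows. Statements on the series, on what has been measured and on what is new or still open speak of the compounds shown alone.

Measured compounds:
Compound 1, `O=C(CSc1nnc(-c2ccncc2)o1)N/N=C/c1ccccc1`: 17300 nM
Compound 2, `O=C(CSc1nnc(-c2ccncc2)o1)N/N=C/c1ccccc1F`: 16000 nM
Compound 3, `O=C(CSc1nnc(-c2ccncc2)o1)N/N=C/c1ccccc1[N+](=O)[O-]`: 24700 nM

Three compounds sharing one core and differing only on the benzylidene ring were tested in a functional assay on HepG2 cells (Homo sapiens) for cytotoxicity, read by MTT assay, with a stated time of 48 h; a higher number here means a weaker inhibitor, a lower number a stronger inhibitor. Compound 3 has the highest number of the three, but its nearest neighbour is compound 1, and both a 1.4-fold higher number from compound 1 to compound 3 (0.15 log units; within the scatter) and a 1.5-fold higher number from compound 2 to compound 3 (0.19 log units; within the scatter) lie within the scatter, so no ordering among the three can be claimed. The remaining step, a 1.1-fold lower number from compound 1 to compound 2 (0.03 log units; within the scatter), is likewise within the scatter.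

Compound 4, `O=C(CSc1nnc(-c2ccncc2)o1)N/N=C/c1ccccc1O`, has not yet been measured in this assay. It differs from compound 3 by hydroxy in place of nitro on an aromatic carbon. Every measured step at this position, whether fluoro or nitro entering in place of hydrogen or nitro in place of fluoro, stayed within the scatter. On that basis the step from compound 3 to compound 4 is expected to be a 1.2-fold lower number from compound 3 to compound 4 (0.09 log units; within the scatter), with no direction beyond the scatter. Compound 4 is therefore estimated at 20000 nM in this assay, in a range from 8000 nM to 50000 nM.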

Compound 4, half-maximal inhibitory concentration: 3510 nM
Beside the measured number, compound 4's estimate is 5.7-fold (0.76 log units) above it; measured number outside the range, below it.
By their numbers in this assay, from the lowest: compound 4; then compounds 2, 1 and 3 (each within the scatter of the next).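

In this assay, among these compounds, hydroxy is the first group at this position to give steps beyond the scatter: a 7.0-fold lower number from compound 3 to compound 4 (0.85 log units; beyond the scatter) when it replaces nitro, a 4.6-fold lower number from compound 2 to compound 4 (0.66 log units; beyond the scatter) when it replaces fluoro and a 4.9-fold lower number from compound 1 to compound 4 (0.69 log units; beyond the scatter) when it replaces hydrogen. All three steps are modest, but they show that this position is not indifferent to its substituent, as hydrogen, fluoro and nitro alone had suggested. No evidence given here bears on what sets hydroxy apart from the other three groups.

The compounds shown leave open whether this shift is particular to hydroxy or would also appear with an amine or a methoxy group in the same place, ortho to a large group. They also do not show whether hydroxy elsewhere on this ring would give a step of similar size.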